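Furan-2-yl in place of 2-phenylethenyl

A few compounds are considered here, and "the series" means these few. Any claim that something is new, unique, unknown or untested is made for them only; others in the source may bear on it.

In a functional assay on MCF7 cells (Homo sapiens) for cytotoxicity, read by sulforhodamine B assay, with a stated time of 48 h (a lower number here means a stronger inhibitor, a higher number a weaker inhibitor), compound 1 `CC(=O)OC[C@H]1O[C@@H](n2cc(CN3C(=O)/C(=C\C=C\c4ccccc4)c4ccccc43)nn2)[C@H](OC(C)=O)[C@@H](OC(C)=O)[C@@H]1OC(C)=O` gives 34100 nM and compound 2 `CC(=O)OC[C@H]1O[C@@H](n2cc(CN3C(=O)/C(=C/C=C/c4ccccc4)c4ccccc43)nn2)[C@H](OC(C)=O)[C@@H](OC(C)=O)[C@@H]1OC(C)=O` gives 53200 nM. These two values lie within the scatter of each other, as a 1.6-fold higher number from compound 1 to compound 2 (0.19 log units; within the scatter) shows, and the pair rests on (the fact that compounds 1 and 2 differ only in the configuration as drawn). Compound 3 `CC(=O)OC[C@H]1O[C@@H](n2cc(CN3C(=O)/C(=C\c4ccco4)c4ccccc43)nn2)[C@H](OC(C)=O)[C@@H](OC(C)=O)[C@@H]1OC(C)=O` carries furan-2-yl in place of 2-phenylethenyl on a double-bonded chain carbon bound to a double-bonded ring carbon. The measured step leaves 2-phenylethenyl untouched and gives no size for this exchange, so no step beyond the scatter is expected in this assay. The expected step is a 1.2-fold higher number from compound 1 to compound 3 (0.07 log units; within the scatter). For compound 3 the estimated value is 40000 nM, with an expected range of 15000 nM to 100000 nM.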

Compound 3, half-maximal inhibitory concentration: 38200 nM
Compound 3: middle estimate off by 1.0-fold (0.02 log units), on the high side, within the range that was stated.
By their numbers in this assay, from the lowest: compounds 1, 3 and 2 (each within the scatter of the next).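

In this assay, furan-2-yl in place of 2-phenylethenyl on a double-bonded chain carbon bound to a double-bonded ring carbon gives a 1.1-fold higher number from compound 1 to compound 3 (0.05 log units; within the scatter). This position therefore takes a five-membered aromatic ring with an oxygen as well as the 2-phenylethenyl group, with no step beyond the scatter. In this pair, neither the six-membered aromatic ring nor the extra double bond of 2-phenylethenyl is needed to keep the number within the scatter.

On these data alone, whether an amine or a carboxylic acid at this position would give a step beyond the scatter remains open. Nothing at hand explains the size of this step.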